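The source may report more compounds than this note shows. Statements on the series, on what has been measured and on what is new or still open speak of the compounds shown alone.

Among the compounds with values here, compound 1 `Cc1ccc(S/C(=C/c2sccc2C)C(=O)c2ccc(Br)cc2)cc1` is one of three compounds measured in a functional assay on DU-145 cells (Homo sapiens) for inhibition, read by trypan blue exclusion, with a stated time of 96 h (on this read-out higher numbers stand for weaker inhibition of growth and lower numbers for stronger inhibition of growth), and in this assay compound 1 gives 50000 nM. Compound 3 `Cc1ccc(S/C(=C/c2sccc2C)C(=O)c2ccc(Cl)cc2)cc1` gives 50000 nM in this assay, and the step of no change at the digits printed from compound 1 to compound 3 (within the scatter) shows no change at the digits reported, within the scatter. Compound 2 `CSc1ccc(/C=C(/SCc2ccc(C)cc2)C(=O)c2ccc(Cl)cc2)cc1` gives 25000 nM in this assay, a value that lies within the scatter of compound 1; the two numbers therefore cannot be placed in order. Compound 1 thus stands level with compound 3 and, on the numbers shown, at the upper end of the set together with compound 3.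

Compound 4 `Cc1ccc(S/C(=C/c2ccc(F)cc2F)C(=O)c2ccc(Br)cc2)cc1` differs from compound 1 as follows: 2,4-difluorophenyl in place of 3-methylthiophen-2-yl on a double-bonded chain carbon bound to a double-bonded chain carbon. Within the data shown here, no measured step bears on this change; the only step recorded, between compound 1 and compound 3, concerns the halogen on the aromatic carbon and stayed within the scatter. With nothing to point either way, compound 4 is expected to sit near compound 1, the estimated step of a 1.3-fold lower number from compound 1 to compound 4 (0.10 log units; within the scatter) being no more than the scatter. Compound 4 is therefore estimated at 40000 nM, with a range from 10000 nM to 100000 nM.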

Compound 4, concentration for 50% growth inhibition: > 100000 nM
Compound 4: only a limit was reported (the forecaster's own chance of this, stated with the estimate: 30%); middle value at least 2.5-fold (0.39 log units) from the limit.
By their numbers in this assay, from the lowest: compounds 2, 1 and 3 (each within the scatter of the next). At a limit, above all of these: compound 4.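

Within the data shown here, this is the first reading of a change on a double-bonded chain carbon bound to a double-bonded chain carbon, and 2,4-difluorophenyl in place of 3-methylthiophen-2-yl gives an at least 2.0-fold higher number from compound 1 to compound 4 (0.30 log units; that floor lies within the scatter) in this assay. On these data alone, that floor does not by itself set the two compounds apart, so the size of the step remains unknown. Compound 4 has a limit of the assay and not a number: the limit of > 100000 nM in this assay, at which 1 of the 4 values shown sits.

The compounds shown leave open whether a plain phenyl or a thiophen-2-yl without the methyl would read like 3-methylthiophen-2-yl or like 2,4-difluorophenyl at this place, so the ring and its substituents cannot be separated in this step. Also open, as far as these compounds go, is how a ring bearing an amine or a carboxylic acid there would read in this assay.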